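Chloro for Fluoro on the Aryl Group at the Ring Nitrogen

A few compounds are considered here, and "the series" means these few. Any claim that something is new, unique, unknown or untested is made for them only; others in the source may bear on it.

Three compounds share one core and differ only in the aryl group carried on an amine nitrogen in a ring. In an assay on CHO cells for displacement of a labelled ligand from adenosine receptor A3 (Homo sapiens), read by scintillation counting, with a stated time of 120 min, tested at 10 uM (on this read-out higher numbers stand for more inhibition at the one concentration tested (going by the name of the read-out) and lower numbers for less inhibition), compound 1 `Nc1scc(CN2CCN(c3ccc(Cl)cc3Cl)CC2)c1C(=O)c1ccc(Cl)cc1` gives 0%. Compound 2 `Nc1scc(CN2CCN(c3ccc(Cl)cc3F)CC2)c1C(=O)c1ccc(Cl)cc1` gives 1% in this assay, and compound 3 `Nc1scc(CN2CCN(c3cc(F)ccc3F)CC2)c1C(=O)c1ccc(Cl)cc1` gives 2%. The steps between them are small: a number 1 percentage points higher from compound 1 to compound 2 (within the scatter), a number 2 percentage points higher from compound 1 to compound 3 (within the scatter) and a number 1 percentage points higher from compound 2 to compound 3 (within the scatter). Compound 3 thus carries the highest of the three numbers, yet every step to it lies within the scatter, so no order among the three can be read from this assay.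

Compound 4 `Nc1scc(CN2CCN(c3cc(Cl)ccc3Cl)CC2)c1C(=O)c1ccc(Cl)cc1` differs from compound 3 in one place: 2,5-dichlorophenyl in place of 2,5-difluorophenyl on an amine nitrogen in a ring. The measured steps that bear on a halogen exchange on this aryl group, a number 1 percentage points higher from compound 1 to compound 2 (within the scatter) and a number 2 percentage points higher from compound 1 to compound 3 (within the scatter), both lie within the scatter, and each gave a change of fluoro against chloro. On that basis no step beyond the scatter is expected in this assay, and the expected step of no change at the digits printed from compound 3 to compound 4 (within the scatter) reflects this. Compound 4 is therefore estimated at 2%, with a range from -6% to 10%.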

Compound 4, a percentage reported as inhibition, at one concentration (the size of the read-out at that concentration, not a potency): 1%
Beside the measured number, compound 4's estimate is 1 percentage points above it; measured number inside the range.
By their numbers in this assay, from the lowest: compounds 1, 2, 4 and 3 (each within the scatter of the next).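

In this assay, among the compounds shown here, 2,5-dichlorophenyl in place of 2,5-difluorophenyl gives a number 1 percentage points lower from compound 3 to compound 4 (within the scatter) and so adds a fluoro-to-chloro exchange at both halogens of one aryl group, which the earlier steps did not cover. The two remaining comparisons also stay within the scatter: 2,5-dichlorophenyl in place of 4-chloro-2-fluorophenyl gives no change at the digits printed from compound 2 to compound 4 (within the scatter) and 2,5-dichlorophenyl in place of 2,4-dichlorophenyl gives a number 1 percentage points higher from compound 1 to compound 4 (within the scatter) and thus extends the flat picture to a dichlorophenyl pair that differs only in halogen placement. No supporting measurement is available to explain these numbers.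

Going by these compounds, whether a methoxy, nitrile or carboxylic acid on this aryl group would give a step beyond the scatter stays open. So does whether replacing the aryl group with a benzyl group or a longer chain on the same nitrogen would do so.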